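Pendant aryl variation on the shared core: compound 3

This account rests on a few compounds, and the source may have more. Where it says the series, first, only, none or still open, it means among the compounds named here.

Measured so far:
compound 1, `O=Cc1ccc(-c2cn3ccnc3c(-c3ccc4ncn(C5CCCCC5)c4c3)n2)cc1` — 16.5%
compound 2, `Clc1ccc(-c2cn3ccnc3c(-c3ccc4ncn(C5CCCCC5)c4c3)n2)cc1` — 15.6%

Both measured compounds share one core and differ only in the group on the pendant phenyl ring. In a functional assay on HL-60 cells (Homo sapiens) for inhibition, read by sulforhodamine B assay, with a stated time of 48 h, tested at 10 uM (a higher number here means more inhibition at the concentration tested (going by the name of the read-out), a lower number less inhibition), compound 1 gives 16.5%, and compound 2 gives 15.6%. The step of a number 0.9 percentage points lower from compound 1 to compound 2 (within the scatter) lies within the scatter, so the two numbers cannot be told apart; compound 2 carries the lower of the two values, but no order between compound 2 and compound 1 can be read from them.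

Compound 3, `c1csc(-c2cn3ccnc3c(-c3ccc4ncn(C5CCCCC5)c4c3)n2)c1`, is not yet measured. Its change from compound 2 is thiophen-2-yl in place of 4-chlorophenyl on an aromatic carbon. Among the measured compounds shown here, the only measured step, from compound 1 to compound 2, is a change of substituent on a phenyl ring that stays in place, and it was within the scatter. For the measured compounds named here, no measured pair replaces the phenyl ring itself, so that step says little about the number compound 3 will give. With nothing pointing either way, the expectation is a step of a number 0.6 percentage points lower from compound 2 to compound 3 (within the scatter), not beyond the scatter. Compound 3 is therefore estimated at 15%, with a range from 3% to 30%.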

Compound 3, a percentage reported as inhibition, at one concentration (the size of the read-out at that concentration, not a potency): 26.6%
Compound 3: the middle estimate sits 11.6 percentage points below what was measured; the measured number falls inside the stated range.
By their numbers in this assay, from the lowest: compounds 2 and 1 (each within the scatter of the next); then compound 3.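

In this assay, exchanging the whole pendant ring at this position moves the number, which the substituent change on the phenyl ring did not do: thiophen-2-yl in place of 4-chlorophenyl gives a number 11 percentage points higher from compound 2 to compound 3 (beyond the scatter), and thiophen-2-yl in place of 4-formylphenyl gives a number 10.1 percentage points higher from compound 1 to compound 3 (beyond the scatter). Both steps are modest, and among these three compounds the two phenyl-bearing compounds stay together while compound 3 stands apart from both. No measurement available here bears on the reason for this difference.

Each step changes the ring and removes the substituent at once, so the compounds shown do not separate the effect of the thiophen-2-yl ring from the loss of the chloro or formyl group; an unsubstituted phenyl, a furan-2-yl or a thiophen-3-yl group at the same position would help to separate them. As far as these compounds go, it also remains open whether a substituent on the thiophene ring, such as an amine or a carboxylic acid, would shift the number further, and all three readings are at a single concentration, so they give no potency.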